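The compounds below may be only part of what the source reports. "The series", "measured", "known", "first", "only" and "open" are said of these compounds alone.

Measured compounds:
compound 1, `Cc1cc(C)cc(Cc2ccc3c(NCCCNCc4ccco4)ccnc3c2)c1`, gives 23 10^-6 cm/s in an ADME assay for permeability, using PAMPA, with a stated time of 30 min, at pH 7.4; on this read-out lower numbers stand for lower permeability and higher numbers for higher permeability.
compound 2, `Fc1ccc(Cc2ccc3c(NCCCNCc4ccco4)ccnc3c2)cc1`, gives 23 10^-6 cm/s in this assay.
compound 3, `COc1ccc(F)cc1CNCCCNc1ccnc2cc(Cc3ccc(F)cc3)ccc12`, gives 23 10^-6 cm/s in this assay.

The three compounds stand level. From compound 2 to compound 1 the change is 3,5-dimethylphenyl in place of 4-fluorophenyl on a saturated chain carbon bound to an aromatic carbon, and the step is no change at the digits printed from compound 2 to compound 1 (within the scatter). From compound 2 to compound 3 the change is 5-fluoro-2-methoxyphenyl in place of furan-2-yl on a saturated chain carbon bound to an amine nitrogen, with the step of no change at the digits printed from compound 2 to compound 3 (within the scatter). Compound 4, `COc1ccc(F)cc1CNCCCNc1ccnc2cc(Cc3cc(C)cc(C)c3)ccc12`, has not yet been measured in this assay. It differs from compound 3 by 3,5-dimethylphenyl in place of 4-fluorophenyl on a saturated chain carbon bound to an aromatic carbon, the same change that was made from compound 2 to compound 1, at the same place. Because that earlier step was no change at the digits printed from compound 2 to compound 1 (within the scatter), the expected step from compound 3 to compound 4 is no change at the digits printed from compound 3 to compound 4 (within the scatter). Compound 4 is therefore expected to give 23 10^-6 cm/s, within the range 13 10^-6 cm/s to 38 10^-6 cm/s.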

Compound 4, apparent permeability: 23 10^-6 cm/s
For compound 4 middle estimate and measured number coincide at the digits printed; the measured number falls inside the stated range.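

For the change to 3,5-dimethylphenyl, this assay gives no change at the digits printed from compound 3 to compound 4 (within the scatter), which matches the earlier step on the other core: the same change on two cores in this assay, no change at the digits printed (within the scatter) from compound 2 to compound 1 and no change at the digits printed (within the scatter) from compound 3 to compound 4, 1.0-fold (0.00 log units) apart, within the scatter of two such steps
For the change to 5-fluoro-2-methoxyphenyl, the result is no change at the digits printed from compound 1 to compound 4 (within the scatter), and again the two cores agree: the same change on two cores in this assay, no change at the digits printed (within the scatter) from compound 2 to compound 3 and no change at the digits printed (within the scatter) from compound 1 to compound 4, 1.0-fold (0.00 log units) apart, within the scatter of two such steps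
This shows that both changes stayed flat on both cores, but it does not show that a change that moves the read-out would carry over in the same way, since none of the steps shown does so.

As far as these compounds go, it remains open whether a carboxylic acid in place of 3,5-dimethylphenyl, or an amine in place of furan-2-yl, would shift the read-out at all. From the compounds shown here alone, it also remains open whether any such shift would be the same on both cores.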